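Sigma-1 binding: nitro for propoxy on the aryl piperazine

The source may report more compounds than this note shows. Statements on the series, on what has been measured and on what is new or still open speak of the compounds shown alone.

Measured so far:
compound 1, `COc1ccc2c(c1)CCC(=O)N2CCCN1CCN(c2cccc(Cl)c2)CC1`: 650 nM
compound 2, `COc1cccc2c1CCC(=O)N2CCCN1CCN(c2cccc([N+](=O)[O-])c2)CC1`: 870 nM
compound 3, `CCCOc1cccc(N2CCN(CCCN3C(=O)CCc4c(Cl)cccc43)CC2)c1`: 370 nM

All three values come from an assay on cell membranes for binding affinity to Sigma non-opioid intracellular receptor 1 (Rattus norvegicus); on this read-out higher numbers stand for weaker inhibition and lower numbers for stronger inhibition. Compound 3 gives the lowest of the three numbers; the gap to compound 1 lies within the usual scatter, so no order between these two can be read, while the gap to compound 2 lies beyond it. Within the data shown here, no two of the measured compounds differ in a single place, so no step between them can be isolated.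

The next compound, compound 4, `O=C1CCc2c(Cl)cccc2N1CCCN1CCN(c2cccc([N+](=O)[O-])c2)CC1`, is derived from compound 3 by the change (nitro in place of propoxy on an aromatic carbon). Among the measured compounds shown here, the only measured compound that carries the entering nitro is compound 2, and it gives the highest of the three numbers, but its core also differs from that of compound 3 and compound 4, so its value cannot be attributed to the nitro alone.

For compound 4 in this assay a modest move toward weaker inhibition is expected, a 1.8-fold higher number from compound 3 to compound 4 (0.24 log units; within the scatter), roughly at the edge of the scatter. The estimated value of compound 4 is 650 nM, with a range from 250 nM to 1700 nM.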

Compound 4, half-maximal inhibitory concentration: 390 nM
Compound 4: the middle estimate sits 1.7-fold (0.22 log units) above what was measured, and the stated range covers the measured number.
By their numbers in this assay, from the lowest: compounds 3, 4, 1 and 2 (each within the scatter of the next, the first and the last beyond it).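

In this assay, nitro in place of propoxy gives a 1.1-fold higher number from compound 3 to compound 4 (0.02 log units; within the scatter) and so, on the core shared by these two compounds, this position meta to a large group does not separate 3-propoxyphenyl from 3-nitrophenyl. With the 3-nitrophenyl held constant, chloro in place of methoxy on an aromatic carbon of the core gives a 2.2-fold lower number from compound 2 to compound 4 (0.35 log units; beyond the scatter) and shows that the high number of compound 2 goes with its methoxy-bearing core and not with the nitro alone, a modest step and the only one in this set that lies beyond the scatter. No measurement at hand accounts for either step.

On these data alone, whether the aryl position stays this flat for other kinds of group, such as an amine, a carboxylic acid or a longer alkoxy chain, remains open, as a single pair of compounds cannot define its tolerance. As far as these compounds go, it is also open whether the chloro and methoxy step keeps its size with propoxy on the aryl piperazine, and whether nitro and propoxy remain matched on a core carrying methoxy.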